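Aldehyde oxidase half-life: oxetane in place of oxane

This account rests on a few compounds, and the source may have more. Where it says the series, first, only, none or still open, it means among the compounds named here.

Within the data shown here, compound 2 `Cn1cc(-c2ccc3nnc(Sc4ccc5ncc(NC6CCOCC6)cc5c4)n3c2)cn1` holds the highest of the two numbers so far in an ADME assay on cytosol from liver for pharmacokinetics, with aldehyde oxidase 1 (Macaca fascicularis) as the target, read by LC-MS, with a stated time of 120 min, tested at 1 uM (a higher number here means that the compound lasts longer, a lower number that the compound disappears faster), giving 4.52 h. Among the measured compounds shown here, compound 1 `Cn1cc(-c2ccc3nnc(Sc4ccc5ncc(NCCO)cc5c4)n3c2)cn1` in this assay gives 0.152 h; the only step between measured compounds, a 30-fold higher number from compound 1 to compound 2 (1.47 log units; beyond the scatter), came with oxan-4-yl in place of 2-hydroxyethyl on a nitrogen on an aromatic ring. Compound 3 `Cn1cc(-c2ccc3nnc(Sc4ccc5ncc(NC6COC6)cc5c4)n3c2)cn1` is not yet measured; it differs from compound 2 by oxetan-3-yl in place of oxan-4-yl on a nitrogen on an aromatic ring. For the measured compounds named here, no measured step exchanges one ring for another on this nitrogen, so the step from compound 1 to compound 2 bears on it only loosely: it shows that a six-membered non-aromatic ring with 1 hetero atom at this place can hold a high number, and a four-membered non-aromatic ring with 1 hetero atom has no precedent here. The expected step is a 1.8-fold lower number from compound 2 to compound 3 (0.26 log units; within the scatter), small and within the scatter. Compound 3 is therefore estimated at 2.5 h, in the range 0.8 h to 8 h.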

Compound 3, half-life: 0.05 h
Compound 3: the middle estimate sits 50-fold (1.70 log units) above what was measured; the measured number lies below the stated range.
By their numbers in this assay, from the lowest: compound 3; then compound 1; then compound 2.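

On a nitrogen on an aromatic ring, the result in this assay separates two non-aromatic rings with 1 hetero atom each: oxetan-3-yl in place of oxan-4-yl gives a 90-fold lower number from compound 2 to compound 3 (1.96 log units; beyond the scatter), so the high number of compound 2 does not carry over from the six-membered ring to the four-membered ring. Oxetan-3-yl in place of 2-hydroxyethyl gives a 3.0-fold lower number from compound 1 to compound 3 (0.48 log units; beyond the scatter), which leaves compound 3 with the lowest number of the three, beneath the open chain as well as the six-membered ring. Nothing at hand accounts for these steps.

Open, going by these compounds, is whether oxolan-3-yl on this nitrogen would lie nearer to compound 2 or to compound 3. Also open, on these data alone, is where a piperidin-4-yl ring, which carries an amine, or a longer chain such as 3-hydroxypropyl would fall.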